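The source may hold more compounds than are shown below. What is called first, only, known or untested is meant among the compounds shown, and "the series" means these compounds.

Compound 1 `COc1cc(C2=CC(=O)N3C[C@H](O[C@H](C)c4cc(C(F)(F)F)cc(C(F)(F)F)c4)[C@@H](c4ccc(F)cc4)C3C2)ccn1`: 1.1 nM
Compound 2 `C[C@@H](O[C@H]1CN2C(=O)C=C(C3=CCC(O)CC3)CC2[C@@H]1c1ccc(F)cc1)c1cc(C(F)(F)F)cc(C(F)(F)F)c1`: 0.18 nM

Within the data shown here, in an assay on CHO cells for displacement of a labelled ligand from Substance-P receptor (Homo sapiens) (a higher number here means a weaker inhibitor, a lower number a stronger inhibitor), compound 2 gives the lowest of the two numbers; the one measured step is a 6.1-fold lower number from compound 1 to compound 2 (0.79 log units; beyond the scatter). Compound 3 `C[C@@H](O[C@H]1CN2C(=O)C=C(C3=CCOCC3)CC2[C@@H]1c1ccc(F)cc1)c1cc(C(F)(F)F)cc(C(F)(F)F)c1` is not yet measured. It differs from compound 2 by a group of 6 heavy atoms (5 carbon, 1 oxygen; one six-membered non-aromatic ring with 1 hetero atom) in place of a group of 7 heavy atoms (6 carbon, 1 oxygen; one six-membered non-aromatic ring of carbon only), on a double-bonded ring carbon. That single step exchanges a different group at this same position, so it bears only loosely on the new change; it shows that the group on this carbon can shift this assay by a modest amount. For compound 3 the expected step is therefore a 2.2-fold higher number from compound 2 to compound 3 (0.35 log units; beyond the scatter), a small rise. The estimate for compound 3 is 0.4 nM, within a range from 0.15 nM to 1.2 nM.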

Compound 3, half-maximal inhibitory concentration: 0.18 nM
Beside the measured number, compound 3's estimate is 2.2-fold (0.35 log units) above it; low and high end bracket the measured number.
By their numbers in this assay, from the lowest: compounds 2 and 3 (each within the scatter of the next); then compound 1.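

In this assay, replacing 4-hydroxycyclohex-1-en-1-yl with a six-membered non-aromatic ring with 1 hetero atom and 0 hydrogen-bond donors gives no change at the digits printed from compound 2 to compound 3 (within the scatter), so at this double-bonded ring carbon, a hydrogen-bond donor on the group is not needed to keep this low number. Set against the 2-methoxypyridin-4-yl group, the same ring gives a 6.1-fold lower number from compound 1 to compound 3 (0.79 log units; beyond the scatter), so compounds 2 and 3, with their non-aromatic rings, both stand apart from compound 1. Nothing shown here explains either step. As far as these compounds go, it remains open whether an amine or a carboxylic acid on this ring would hold the number. An open alkyl chain in place of the ring, or a fully saturated ring without its double bond, is equally untested among the compounds shown.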